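Replacing the dichlorobenzyl group of compound 1 with a hexyl chain

A few compounds are considered here, and "the series" means these few. Any claim that something is new, unique, unknown or untested is made for them only; others in the source may bear on it.

Working notes on three measured compounds and one open position. Compound 1 `Nc1nc(O)c2c(n1)n(C1OC(CO)[C@@H](O)[C@H]1O)c(=O)n2Cc1ccc(Cl)c(Cl)c1` carries a 3,4-dichlorobenzyl group on the shared core. In a functional assay on the whole organism with Mus musculus as the target (a lower number here means a smaller maximal response, a higher number a larger maximal response), compound 1 gives 0%, the lowest of the three numbers at hand. Compound 3 `Cn1c(=O)n(C2OC(CI)[C@@H](O)[C@H]2O)c2nc(N)nc(O)c21` gives 4% in this assay, a number within the scatter of compound 1, so no order between the two can be stated. Compound 2 `C=CCn1c(=O)n(C2C[C@H](O)C(CO)O2)c2nc(N)nc(O)c21` gives 131% in this assay, a number far beyond the scatter above compound 1; compound 2 also differs from compound 1 in its sugar part, so the two cannot be compared on a single change.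

Compound 4 `CCCCCCn1c(=O)n(C2OC(CO)[C@@H](O)[C@H]2O)c2nc(N)nc(O)c21` has not been measured. It differs from compound 1 as follows: pentyl in place of 3,4-dichlorophenyl on a saturated chain carbon bound to an aromatic nitrogen. For the measured compounds named here, no pair of measured compounds differing in one place is available, so the size of this step is not anchored. The small substituents of compound 2 and compound 3 give widely different responses, which leaves the direction open. A moderate rise from the floor of compound 1 is expected, with a wide range. For compound 4 the estimated value is 35% (range 0% to 110%), which would be a step of a number 35 percentage points higher from compound 1 to compound 4 (beyond the scatter).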

Compound 4, largest response reached (reported as maximal response), in percent of the reference or control that the assay uses: 11%
For compound 4 the middle estimate is 24 percentage points above the measured one; the measured number falls inside the stated range.
By their numbers in this assay, from the lowest: compounds 1, 3 and 4 (each within the scatter of the next, the first and the last beyond it); then compound 2.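

For the compounds shown here, at the place on a saturated chain carbon bound to an aromatic nitrogen, pentyl in place of 3,4-dichlorophenyl gives the only step that can be read on one change: in this assay the result is a number 11 percentage points higher from compound 1 to compound 4 (beyond the scatter), a modest step. With the sugar part held the same, the aromatic ring and both chlorines can therefore go without the response reaching a high level, as compound 4 gives only 11% in this assay. No measurement at hand bears on the reason for this step.

The other pairs differ in more than one place, so their steps cannot be read, and the high value of compound 2 at 131% cannot be assigned to its allyl group or to its sugar part. Still open, on these data alone, is whether allyl on the sugar part of compound 1 would raise the response, and whether a longer chain such as octyl, or a carboxylic acid or an amine in place of the hexyl chain, would move it.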